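Swapping Chloro for Fluoro on the Aromatic Ring

This account rests on a few compounds, and the source may have more. Where it says the series, first, only, none or still open, it means among the compounds named here.

For the measured compounds named here, compound 3 `COC(=O)C(=O)/C=C(\O)c1ccc(Cl)cc1` gives 38% in an assay for inhibition of kynurenine 3-monooxygenase (Rattus norvegicus), tested at 10 uM (a lower number here means less inhibition, a higher number more inhibition at the concentration tested (going by the name of the read-out)), the highest of the three numbers measured so far. Compound 1 `COC(=O)C(=O)/C=C(\O)c1ccccc1Cl` gives 31% in this assay, which lies within the scatter of compound 3, while compound 2 `COC(=O)C(=O)/C=C(\O)c1ccccc1[N+](=O)[O-]` gives 1%, beyond the scatter below it. Compound 4 `COC(=O)C(=O)/C=C(\O)c1ccc(F)cc1` differs from compound 3 by fluoro in place of chloro on an aromatic carbon. Going by the values given here, the only measured step, a number 30 percentage points lower from compound 1 to compound 2 (beyond the scatter), concerns a different change, so nothing measured directly guides an exchange of one halogen for another. With no sign of a large effect from such a swap, compound 4 is expected to remain close, with a step of a number 10 percentage points lower from compound 3 to compound 4 (within the scatter) that should lie within the scatter. Compound 4 is therefore estimated at 28%, ranging from 10% to 45%.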

Compound 4, a percentage reported as inhibition, at one concentration (the size of the read-out at that concentration, not a potency): 22%
Compound 4: middle estimate off by 6 percentage points, on the high side, within the range that was stated.
By their numbers in this assay, from the lowest: compound 2; then compounds 4, 1 and 3 (each within the scatter of the next, the first and the last beyond it).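

In this assay, for the compounds shown here, the two halogens are not interchangeable at this aromatic carbon: fluoro in place of chloro gives a number 16 percentage points lower from compound 3 to compound 4 (beyond the scatter) and is the first measured exchange of one halogen for another. Replacing a single atom at this position is therefore enough to shift the number, although the shift is modest. No measurement here accounts for the difference.

Still open, going by these compounds, is whether bromo or an amine on the same carbon would give a higher or lower number. The effect of a carboxylic acid in place of the methyl ester is also unknown.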